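The source may hold more compounds than are shown below. What is called first, only, known or untested is meant among the compounds shown, and "the series" means these compounds.

Measured in a functional assay on CLL cells (Homo sapiens) for cytotoxicity, read by MTT assay, with a stated time of 48 h; a lower number here means that less compound is needed, a higher number that more compound is needed for the effect:
compound 1 `C=C(CC)C(=O)c1ccc(OCC(=O)Nc2ccc(C(=O)O)cc2)c(Cl)c1Cl` gives 5000 nM;
compound 2 `C=C(CC)C(=O)c1ccc(OCC(=O)NCO[N+](=O)[O-])c(Cl)c1Cl` gives 4100 nM;
compound 3 `C=C(CC)C(=O)c1ccc(OCC(=O)Nc2ccc(O)c(Cl)c2)c(Cl)c1Cl` gives 5500 nM.

Compound 1 stands among the three with no separation beyond the scatter: a 1.1-fold higher number from compound 1 to compound 3 (0.04 log units; within the scatter) and a 1.2-fold lower number from compound 1 to compound 2 (0.09 log units; within the scatter). The pair of compound 2 and compound 3 likewise shows a 1.3-fold higher number from compound 2 to compound 3 (0.13 log units; within the scatter).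

Compound 4 `C=C(CC)C(=O)c1ccc(OCC(=O)Nc2ccc(/C=C/C(=O)OCC)cc2)c(Cl)c1Cl` differs from compound 1 in one place: 2-(ethoxycarbonyl)ethenyl in place of carboxy on an aromatic carbon. For the measured compounds named here, no measured step alters the carboxy group itself; the two steps that start from compound 1 exchange the whole substituent on the amide-type nitrogen and stay within the scatter. On that basis no step beyond the scatter is expected in this assay, in either direction: a 1.1-fold lower number from compound 1 to compound 4 (0.05 log units; within the scatter). Compound 4 is therefore estimated at 4500 nM, in the range 2000 nM to 10000 nM.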

Compound 4, half-maximal effective concentration: 1700 nM
Beside the measured number, compound 4's estimate is 2.6-fold (0.42 log units) above it; measured number below the stated range.
By their numbers in this assay, from the lowest: compound 4; then compounds 2, 1 and 3 (each within the scatter of the next).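

In this assay, for the compounds shown here, 2-(ethoxycarbonyl)ethenyl in place of carboxy gives the first step in this set beyond the scatter, though a modest one: a 2.9-fold lower number from compound 1 to compound 4 (0.47 log units; beyond the scatter). This aromatic carbon, para to a large group, therefore responds to substitution in this assay, unlike the exchanges on the amide-type nitrogen linking compound 1, compound 2 and compound 3. Nothing available bears on the reason for this step.

On these data alone, the ethenyl link and the ethyl ester enter together, so their separate contributions stay open. A 2-carboxyethenyl group or a simple ethyl ester on the same carbon would separate them.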